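Swapping an aromatic chloro for nitro: compound 4 expected

This account rests on a few compounds, and the source may have more. Where it says the series, first, only, none or still open, it means among the compounds named here.

Measured so far:
compound 1 `CC1=CC[C@H](C(C)(C)NC(=S)N/N=C/c2ccccc2)CC1` — 84400 nM
compound 2 `CC1=CC[C@H](C(C)(C)NC(=S)N/N=C/c2ccccc2O)CC1` — 17500 nM
compound 3 `CC1=CC[C@H](C(C)(C)NC(=S)N/N=C/c2ccccc2Cl)CC1` — 98300 nM

These three compounds share one core and differ only in what sits on the aromatic ring at the far end. In a functional assay on MCF7 cells (Homo sapiens) for inhibition, read by sulforhodamine B assay, with a stated time of 48 h (a lower number here means a stronger inhibitor of growth, a higher number a weaker inhibitor of growth), compound 3 gives the highest of the three numbers, but its gap to compound 1 is within the scatter: a 1.2-fold higher number from compound 1 to compound 3 (0.07 log units; within the scatter). Compound 2 stands apart, with a 5.6-fold higher number from compound 2 to compound 3 (0.75 log units; beyond the scatter) and a 4.8-fold lower number from compound 1 to compound 2 (0.68 log units; beyond the scatter).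

The next compound, compound 4 `CC1=CC[C@H](C(C)(C)NC(=S)N/N=C/c2ccccc2[N+](=O)[O-])CC1`, differs from compound 3 in one place: nitro in place of chloro on an aromatic carbon. The new group sits on the aromatic carbon ortho to a large group, where compound 3 carries chloro.

For the measured compounds named here, no measured step introduces a nitro, so the evidence is indirect. The two steps that touch this position show that chloro changes nothing beyond the scatter while hydroxy lowers the number modestly. A nitro carries two acceptors and no donor, so the hydroxy result need not carry over. The expected step in this assay from compound 3 to compound 4 is therefore small and uncertain in direction: a 1.6-fold lower number from compound 3 to compound 4 (0.21 log units; within the scatter). Compound 4 is estimated at 60000 nM, within a range from 15000 nM to 200000 nM.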

Compound 4, concentration for total growth inhibition: 94700 nM
Beside the measured number, compound 4's estimate is 1.6-fold (0.20 log units) below it, within the range that was stated.
By their numbers in this assay, from the lowest: compound 2; then compounds 1, 4 and 3 (each within the scatter of the next).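

In this assay, nitro on this aromatic carbon, ortho to a large group, behaves like the two groups without hydroxy: replacing chloro gives a 1.0-fold lower number from compound 3 to compound 4 (0.02 log units; within the scatter) and replacing hydrogen gives a 1.1-fold higher number from compound 1 to compound 4 (0.05 log units; within the scatter) in the same assay. Hydroxy therefore stands apart from all three other groups shown, with a 5.4-fold higher number from compound 2 to compound 4 (0.73 log units; beyond the scatter) as the step to nitro, so the two groups that differ from each other in size and in counted hydrogen-bond acceptors, chloro and nitro, both sit level with plain hydrogen. No measurement at hand explains why hydroxy alone gives the lower number.

An amine, a methoxy or a carboxylic acid on this same carbon would test whether hydroxy is truly alone here or whether other groups also separate from hydrogen, chloro and nitro. Also open, going by these compounds, is whether hydroxy would give a similar step on another carbon of the ring, and whether any group here could bring the number far below that of compound 2, at 17500 nM in this assay.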